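Fluoro in Place of Chloro at the Assay Limit

The source may report more compounds than this note shows. Statements on the series, on what has been measured and on what is new or still open speak of the compounds shown alone.

Compound 1 (`Cc1ccc2nc(-c3ccc(Cl)cc3)cc(C(=O)OCc3ccccc3)c2c1`) and compound 2 (`Cc1ccc2nc(-c3ccc(Cl)cc3)cc(COCc3ccccc3)c2c1`) were both tested in a functional assay on MDA-MB-231 cells (Homo sapiens) for antiproliferative activity, read by MTT assay, with a stated time of 48 h; a lower number here means a stronger inhibitor, a higher number a weaker inhibitor. Compound 1 gives > 100000 nM, which is a limit of the assay and not a number. Compound 2 gives > 100000 nM, which is also a limit. Compound 2 therefore has no exact value, and the shared picture is the limit of > 100000 nM in this assay, at which 2 of the 2 values shown sit.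

Compound 3 (`Cc1ccc2nc(-c3ccc(F)cc3)cc(COCc3ccccc3)c2c1`) differs from compound 2 in one place: fluoro in place of chloro on an aromatic carbon. This puts fluoro in place of chloro on an aromatic carbon, turning 4-chlorophenyl into 4-fluorophenyl.

Going by the values given here, no measured pair yet shows what this exchange does. With compound 2 resting at > 100000 nM, a limit, the expectation is no step beyond the scatter in this assay. The estimated change is a number no higher from compound 2 to compound 3 (the limit leaves the size open). Compound 3 is expected to give about 100000 nM, within an estimated range of 30000 nM to 200000 nM.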

Compound 3, half-maximal inhibitory concentration: > 100000 nM
Compound 3: only a limit was reported; the forecaster's own chance of this, stated with the estimate: 70%; the middle value lies on the limit itself.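

Compound 2 and compound 3 both give only a limit, so no step can be read between them. What the exchange of 4-chlorophenyl for 4-fluorophenyl does to activity stays open, as does which structure would give an exact number, since compound 1, compound 2 and compound 3 share one result: the limit of > 100000 nM in this assay, at which 3 of the 3 values shown sit.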